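Cytotoxicity across a small urea series: fluoro for methoxycarbonyl

The source may hold more compounds than are shown below. What is called first, only, known or untested is meant among the compounds shown, and "the series" means these compounds.

The compounds share a urea-linked core and were read in an ADME assay on HEK293 cells (Homo sapiens) for cytotoxicity, with a stated time of 72 h; a lower number here means that less compound is needed, a higher number that more compound is needed for the effect. Compound 1 `Cc1cc(NC(=O)Nc2ccc(N)cc2)c2ccccc2n1` carries an amino group; in this assay compound 1 reaches only > 25000 nM, a limit of the assay and not a number. Compound 2 `Cc1cc(NC(=O)Nc2ccc(F)c(F)c2)c2ccccc2n1` carries two fluorines; in this assay compound 2 likewise gives the limit > 25000 nM. Going by the values given here, compound 3 `COC(=O)c1cccc(NC(=O)Nc2cc(C)nc3ccccc23)c1` carries a methoxycarbonyl group; in this assay compound 3 gives 26000 nM, which is the only actual number among the three values shown. The other two values are limits: the limit of > 25000 nM in this assay, at which 2 of the 3 values shown sit. Among the compounds with values here, compound 3 therefore stands at essentially the same place as the limits, with no compound showing cytotoxicity that the assay can quantify well.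

Compound 4 `Cc1cc(NC(=O)Nc2cccc(F)c2)c2ccccc2n1` has not yet been measured. It differs from compound 3 as follows: fluoro in place of methoxycarbonyl on an aromatic carbon. Within the data shown here, no step between measured compounds is available, so the expectation rests on where compound 3 stands and on the limits. Because all three values sit at or near (the limit of > 25000 nM in this assay, at which 2 of the 3 values shown sit), the step from compound 3 to compound 4 is expected to be none beyond the scatter, a 1.2-fold higher number from compound 3 to compound 4 (0.06 log units; within the scatter). Compound 4 is accordingly estimated at 30000 nM in this assay, with a range from 18000 nM to 70000 nM, and the assay is more likely than not to report only a limit for compound 4.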

Compound 4, half-maximal effective concentration: > 25000 nM
Compound 4: a limit, no number; the forecaster's own chance of this, stated with the estimate: 75%; the middle value is on the limit's open side.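

In this assay compound 4 gives > 25000 nM, a limit of the assay and not a number. The steps to compound 4 from compound 1, compound 2 and compound 3 therefore cannot be read: the limit of > 25000 nM in this assay, at which 3 of the 4 values shown sit.

The compounds shown leave open where compound 1, compound 2 and compound 4 stand in actual numbers, and whether any of these changes moves the read-out in this assay at all.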